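Swapping the Pyridinyloxy Arm for Benzyl(methyl)amino

A few compounds are considered here, and "the series" means these few. Any claim that something is new, unique, unknown or untested is made for them only; others in the source may bear on it.

Compound 2 `OC[C@H]1O[C@@H](n2cnc3c(COc4ccccn4)ncnc32)[C@H](O)[C@@H]1O` carries a (pyridin-2-yl)oxy group on a saturated chain carbon bound to an aromatic carbon. In a functional assay on HL-60 cells (Homo sapiens) for inhibition, read by XTT assay, with a stated time of 72 h (on this read-out higher numbers stand for weaker inhibition and lower numbers for stronger inhibition), compound 2 gives 14300 nM, the highest of the two numbers shown, while its only neighbour, compound 1 `OC[C@H]1O[C@@H](n2cnc3c(Cn4ccc5ccccc54)ncnc32)[C@H](O)[C@@H]1O`, gives 9100 nM in this assay. Among the measured compounds shown here, the single measured step, a 1.6-fold higher number from compound 1 to compound 2 (0.20 log units; within the scatter), leaves the two numbers within the scatter. Compound 3 `CN(Cc1ccccc1)Cc1ncnc2c1ncn2[C@@H]1O[C@H](CO)[C@@H](O)[C@H]1O` differs from compound 2 in one place: benzyl(methyl)amino in place of (pyridin-2-yl)oxy on a saturated chain carbon bound to an aromatic carbon. For the measured compounds named here, only the step from compound 1 to compound 2 bears on this change, and it lies within the scatter; no measured step covers benzyl(methyl)amino entering at this place. Compound 3 is therefore expected to give 12000 nM in this assay, with a range from 4500 nM to 32000 nM, which means an expected step of a 1.2-fold lower number from compound 2 to compound 3 (0.08 log units; within the scatter), not beyond the scatter.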

Compound 3, half-maximal inhibitory concentration: 2400 nM
Compound 3: middle estimate off by 5.0-fold (0.70 log units), on the high side; the whole stated range lies above it.
By their numbers in this assay, from the lowest: compound 3; then compounds 1 and 2 (each within the scatter of the next).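

In this assay, among the compounds shown here, the earlier compounds left open whether a change on this saturated chain carbon bound to an aromatic carbon could move the number beyond the scatter, and benzyl(methyl)amino in place of (pyridin-2-yl)oxy does so, with a 6.0-fold lower number from compound 2 to compound 3 (0.78 log units; beyond the scatter). Benzyl(methyl)amino in place of 1H-indol-1-yl points the same way, with a 3.8-fold lower number from compound 1 to compound 3 (0.58 log units; beyond the scatter), so among these three groups benzyl(methyl)amino alone stands apart, while compound 1 and compound 2 remain within the scatter of each other. No measurement at hand offers a reason for these steps.

The compounds shown do not separate the part played by the amine nitrogen, its methyl and its benzyl group, as a plain benzylamino or a dimethylamino group at this place might. Going by these compounds, how a longer chain between the nitrogen and the phenyl ring would compare also stays open.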